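The source may report more compounds than this note shows. Statements on the series, on what has been measured and on what is new or still open speak of the compounds shown alone.

Series notes. Compound 1 `Cc1ccc(-c2c(C)nn(-c3nc(-c4ccc(Cl)c(Cl)c4)c(SC(C)C)s3)c2C(=O)O)cc1` gives 3800 nM in a functional assay on BJAB cells (Homo sapiens) for antiproliferative activity, with a stated time of 4 days; a higher number here means that more compound is needed for the effect, a lower number that less compound is needed. Compound 2 `Cc1cccc(-c2c(C)nn(-c3nc(-c4ccc(Cl)c(Cl)c4)c(SC(C)C)s3)c2C(=O)O)c1` gives 17000 nM in this assay. Compound 3 `Cc1nn(-c2nc(-c3ccc(Cl)c(Cl)c3)c(SC(C)C)s2)c(C(=O)O)c1-c1ccncc1` gives 5900 nM in this assay, the second highest of the three numbers: its gap to compound 1 lies within the scatter, its gap to compound 2 beyond it. Among the measured steps, a 4.5-fold higher number from compound 1 to compound 2 (0.65 log units; beyond the scatter) is a modest rise, a 1.6-fold higher number from compound 1 to compound 3 (0.19 log units; within the scatter) stays within the scatter, and a 2.9-fold lower number from compound 2 to compound 3 (0.46 log units; beyond the scatter) is a modest fall.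

Compound 4 `Cc1nn(-c2nc(-c3ccc(Cl)c(Cl)c3)c(SC(C)C)s2)c(C(=O)O)c1-c1cccc(Cl)c1` is the next member: 3-chlorophenyl in place of pyridin-4-yl on an aromatic carbon. Among the measured compounds shown here, two measured steps bear on this change. The step of a 1.6-fold higher number from compound 1 to compound 3 (0.19 log units; within the scatter) says that swapping pyridin-4-yl for a six-membered carbon-only ring carrying one group need not move the number at all. The step of a 2.9-fold lower number from compound 2 to compound 3 (0.46 log units; beyond the scatter) says that when that one group sits as in 3-methylphenyl, the carbon-only ring gives the higher number, by a modest margin. The entering 3-chlorophenyl resembles compound 2 in this respect, so a modest rise is expected rather than none, with the caveat that chlorine has not been tested in this position in the series.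

For compound 4 the expected step is a 2.0-fold higher number from compound 3 to compound 4 (0.31 log units; beyond the scatter). Compound 4 is estimated at 12000 nM in this assay, within a range from 4000 nM to 40000 nM.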

Compound 4, half-maximal effective concentration: 13600 nM
For compound 4 the middle estimate is 1.1-fold (0.05 log units) below the measured one, and the stated range covers the measured number.
By their numbers in this assay, from the lowest: compounds 1 and 3 (each within the scatter of the next); then compounds 4 and 2 (each within the scatter of the next).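

In this assay there is a 2.3-fold higher number from compound 3 to compound 4 (0.36 log units; beyond the scatter) with 3-chlorophenyl in place of pyridin-4-yl, so a second carbon-only ring, now bearing chlorine, also gives a number beyond the scatter of the pyridin-4-yl compound. Chloro in place of methyl on that ring makes little difference, with a 1.3-fold lower number from compound 2 to compound 4 (0.10 log units; within the scatter), whereas a 3.6-fold higher number from compound 1 to compound 4 (0.55 log units; beyond the scatter) separates 3-chlorophenyl from 4-methylphenyl; among the four compounds, the two with the ring group set as in 3-methylphenyl and 3-chlorophenyl both stand beyond the scatter of the other two, and neither compound goes against this. No measurement shown here accounts for these differences.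

Still open, going by these compounds, is whether 4-chlorophenyl would stand with 4-methylphenyl, which would show if the same split holds for chloro as for methyl. Also open, on these data alone, is how a methoxy group or an amine on the phenyl ring, or pyridin-3-yl in place of pyridin-4-yl, would read at this position on the five-membered ring, with the carboxy group and the methyl group kept in place.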